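The source may report more compounds than this note shows. Statements on the series, on what has been measured and on what is new or still open speak of the compounds shown alone.

In a functional assay on HepG2 cells (Homo sapiens) for inhibition, read by fluorescence and resazurin assay, with a stated time of 72 h (a higher number here means a weaker inhibitor, a lower number a stronger inhibitor), compound 1 (`O=C(Nc1ccccc1)Nc1ccc(Nc2nccc(Nc3ccc4cn[nH]c4c3)n2)cc1`) gives 11000 nM and compound 2 (`c1cc(Nc2ccc3cn[nH]c3c2)nc(Nc2ccc(Cn3cncn3)cc2)n1`) gives 18000 nM. For the measured compounds named here, these are the only two numbers so far, and they lie within the scatter of each other, so compound 2 cannot be separated from compound 1. Compound 3 (`O=C(Nc1ccc(F)cc1)Nc1ccc(Nc2nccc(Nc3ccc4cn[nH]c4c3)n2)cc1`) has not yet been measured. Its difference from compound 2 is ((4-fluorophenyl)carbamoyl)amino in place of (1H-1,2,4-triazol-1-yl)methyl on an aromatic carbon. Thus ((4-fluorophenyl)carbamoyl)amino stands in place of (1H-1,2,4-triazol-1-yl)methyl on an aromatic carbon, para to a large group.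

Going by the values given here, one measured step bears on this change: a 1.6-fold higher number from compound 1 to compound 2 (0.21 log units; within the scatter). That step links the same (1H-1,2,4-triazol-1-yl)methyl group to the (phenylcarbamoyl)amino group of compound 1, which lacks only the fluorine of the entering group. Among the compounds with values here, no measured step shows what that fluorine does on its own, which leaves the estimate uncertain. Compound 3 is therefore expected to lie close to compound 1, at 11000 nM. The expected change, estimated as a 1.8-fold lower number from compound 2 to compound 3 (0.26 log units; within the scatter), does not go beyond the scatter. For compound 3 the estimated value is 10000 nM, with an expected range of 4000 nM to 22000 nM.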

Compound 3, half-maximal inhibitory concentration: 3500 nM
Estimate against measurement, compound 3: 2.9-fold (0.46 log units) above; the whole stated range lies above it.
By their numbers in this assay, from the lowest: compound 3; then compounds 1 and 2 (each within the scatter of the next).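

In this assay, for the compounds shown here, fluoro in place of hydrogen on an aromatic carbon, the only change that turns the (phenylcarbamoyl)amino group into the ((4-fluorophenyl)carbamoyl)amino group, gives a 3.1-fold lower number from compound 1 to compound 3 (0.50 log units; beyond the scatter), so this one atom separates two compounds that otherwise share everything. The exchange at the position on the aromatic carbon, para to a large group, now also reads differently: ((4-fluorophenyl)carbamoyl)amino in place of (1H-1,2,4-triazol-1-yl)methyl gives a 5.1-fold lower number from compound 2 to compound 3 (0.71 log units; beyond the scatter), whereas the unfluorinated group could not be told apart from (1H-1,2,4-triazol-1-yl)methyl, with a 1.6-fold higher number from compound 1 to compound 2 (0.21 log units; within the scatter). Among these three compounds, then, only the fluorinated group stands clear of the others, and no measurement here accounts for why the fluorine has this effect.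

The compounds shown leave open whether this step belongs to fluoro in particular or would also follow from chloro, methyl or methoxy in its place on the same phenyl ring. They also leave open whether fluoro would give a similar step on a group other than (phenylcarbamoyl)amino, such as a simple benzamide, with the rest of the core unchanged.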